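Swapping Ethoxy for Methyl on the Ester Carbonyl

The source may hold more compounds than are shown below. What is called first, only, known or untested is meant among the compounds shown, and "the series" means these compounds.

Compound 1, `C=C(C)[C@@H]1CC=C(Cn2cc(COc3ccc(C4NC(=O)NC(C)=C4C(=O)OCC)cc3)nn2)CC1`, gives 43100 nM in a functional assay on MCF7 cells (Homo sapiens) for inhibition, read by sulforhodamine B assay, with a stated time of 48 h; on this read-out higher numbers stand for weaker inhibition of growth and lower numbers for stronger inhibition of growth.
Compound 2, `C=C(C)[C@@H]1CC=C(Cn2cc(COc3cc(C4NC(=O)NC(C)=C4C(=O)OCC)ccc3OC)nn2)CC1`, gives > 100000 nM in this assay; this is a limit of the assay, not a number.
Compound 3, `C=C(C)[C@@H]1CC=C(Cn2cc(COc3ccc(C4NC(=O)NC(C)=C4C(=O)OCC)cc3OC)nn2)CC1`, gives 82500 nM in this assay.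

Of the two actual numbers, compound 3 has the higher one; its nearest neighbour is compound 1, and the step of a 1.9-fold higher number from compound 1 to compound 3 (0.28 log units; within the scatter) is within the scatter, so the two cannot be told apart. Compound 4, `C=C(C)[C@@H]1CC=C(Cn2cc(COc3ccc(C4NC(=O)NC(C)=C4C(C)=O)cc3OC)nn2)CC1`, differs from compound 3 by methyl in place of ethoxy on a carbonyl carbon. For the measured compounds named here, none of the measured steps touches this carbonyl: the only measured step, a 1.9-fold higher number from compound 1 to compound 3 (0.28 log units; within the scatter), concerns a methoxy on an aromatic carbon, so there is no measured basis for a direction. The expectation is therefore no step beyond the scatter in this assay. Compound 4 is estimated at 80000 nM, with a range from 30000 nM to 200000 nM. The expected step of a 1.0-fold lower number from compound 3 to compound 4 (0.01 log units; within the scatter) is estimated to stay within the scatter. Since one of the three values sits at the limit of > 100000 nM in this assay, at which 1 of the 3 values shown sits, there is also a fair chance that compound 4 returns only a limit.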

Compound 4, concentration for total growth inhibition: 53300 nM
For compound 4 the middle estimate is 1.5-fold (0.18 log units) above the measured one; the measured number falls inside the stated range.
By their numbers in this assay, from the lowest: compounds 1, 4 and 3 (each within the scatter of the next). At a limit, above all of these: compound 2.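

Changing ethoxycarbonyl to acetyl gives a 1.5-fold lower number from compound 3 to compound 4 (0.19 log units; within the scatter) in this assay. For the compounds shown here, this is the first look at the carbonyl carbon, and it shows that ethoxy, with its 3 heavy atoms, can give way to methyl, with 1, without any change that can be read in this assay, so the full ester is not required to keep a measurable number here. Compound 2 remains the only compound at a limit, which is not a number: the limit of > 100000 nM in this assay, at which 1 of the 4 values shown sits.

As far as these compounds go, whether a carboxylic acid, an amine or a longer chain such as butoxy on this carbonyl carbon would move the number beyond the scatter remains open. From the compounds shown here alone, this is also a single pair, so it is unknown whether the same swap would behave alike on compound 1, which lacks the methoxy on the aromatic carbon.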